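The source may hold more compounds than are shown below. What is called first, only, known or untested is meant among the compounds shown, and "the series" means these compounds.

In a functional assay on NCI-H1299 cells (Homo sapiens) for inhibition, read by CCK-8 assay, with a stated time of 72 h, tested at 1 uM (a lower number here means a weaker effect, a higher number a stronger effect of the compound at the concentration tested), the three measured compounds stand as follows: compound 1 `CN(C)C(=O)c1cc2cnc(Nc3ccc(C(=O)NCCCCN=C=S)cc3)nc2n1C1CCCC1` gives 55.2%; compound 2 `CN(C)C(=O)c1cc2cnc(Nc3ccc(C(=O)NCCCCCCCN=C=S)cc3)nc2n1C1CCCC1` gives 75.7%; compound 3 `CN(C)C(=O)c1cc2cnc(Nc3ccc(C(=O)NCCCCN=C=S)cc3O)nc2n1C1CCCC1` gives 10.7%.

Compound 1 therefore stands second highest of the three, with compound 2 nearest and compound 3 furthest from it. Compound 4 `CN(C)C(=O)c1cc2cnc(Nc3ccc(NC(=O)CCCCCN=C=S)cc3)nc2n1C1CCCC1` differs from compound 1 in one place: a group of 11 heavy atoms (7 carbon, 2 nitrogen, 1 oxygen, 1 sulfur; no ring) in place of a group of 10 heavy atoms (6 carbon, 2 nitrogen, 1 oxygen, 1 sulfur; no ring), on an aromatic carbon. Of the two measured steps, the one that bears on this is a number 20.5 percentage points higher from compound 1 to compound 2 (beyond the scatter), where the group on the saturated chain carbon also grew by several atoms. The step of a number 44.5 percentage points lower from compound 1 to compound 3 (beyond the scatter) concerns a hydroxy on an aromatic carbon and does not speak to the change here. For the measured compounds named here, the reversal within the amide-type linkage has no measured counterpart, so the expectation rests only on the growth of the chain. On that basis a modest rise is expected, a number 7.8 percentage points higher from compound 1 to compound 4 (within the scatter). Compound 4 is thus estimated at 63%, within a range of 42% to 80%.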

Compound 4, a percentage reported as inhibition, at one concentration (the size of the read-out at that concentration, not a potency): 34.3%
Compound 4: middle estimate off by 28.7 percentage points, on the high side, and the stated range ends above it.
By their numbers in this assay, from the lowest: compound 3; then compound 4; then compound 1; then compound 2.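

Replacing the group of 10 heavy atoms with the group of 11 heavy atoms on an aromatic carbon, para to a large group, gives a number 20.9 percentage points lower from compound 1 to compound 4 (beyond the scatter) in this assay. At this position, then, a larger group does not go with a higher number, unlike the chain growth in a number 20.5 percentage points higher from compound 1 to compound 2 (beyond the scatter). Nothing available accounts for this direction.

The compounds shown do not separate the effect of the reversed amide-type linkage from that of chain length, as both change together in compound 4. As far as these compounds go, a longer chain on the reversed linkage remains open.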